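Ring Size Change in a Dithiocarbamate Chalcone Series

A few compounds are considered here, and "the series" means these few. Any claim that something is new, unique, unknown or untested is made for them only; others in the source may bear on it.

Measured so far:
Compound 1, `COc1cc(/C=C/C(=O)c2ccc(OCCCSC(=S)N3CCCC3)cc2)cc(OC)c1OC`, gives 12800 nM in a functional assay on SK-N-SH cells (Homo sapiens) for inhibition, read by MTT assay, with a stated time of 72 h; on this read-out lower numbers stand for stronger inhibition and higher numbers for weaker inhibition.
Compound 2, `O=C(/C=C/c1ccc(Cl)cc1)c1ccc(OCCSC(=S)N2CCCC2)cc1`, gives 18300 nM in this assay.

Going by the values given here, only these two numbers are known, and they sit within the usual scatter of each other, so compound 1 cannot be set ahead of or behind compound 2 on this assay; the two compounds also differ in more than one place, so no single step between them can be drawn.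

Compound 3, `COc1cc(/C=C/C(=O)c2ccc(OCCSC(=S)N3CCCCC3)cc2)cc(OC)c1OC`, has not yet been measured. It differs from compound 1 in a group near the aromatic oxygen: a group of 9 heavy atoms (6 carbon, 1 nitrogen, 2 sulfur; one six-membered non-aromatic ring with 1 hetero atom) in place of a group of 9 heavy atoms (6 carbon, 1 nitrogen, 2 sulfur; one five-membered non-aromatic ring with 1 hetero atom), on a saturated chain carbon, two bonds along the chain from an oxygen on an aromatic ring. The two structures contain the same atoms, joined differently, so this is a modest rearrangement rather than an addition or removal of anything.

Among the compounds with values here, with no measured step of this kind to draw on, the expectation is a step of a 1.1-fold lower number from compound 1 to compound 3 (0.03 log units; within the scatter), that is, none beyond the scatter. Compound 3 is therefore estimated to give 12000 nM in this assay, with a range from 5000 nM to 30000 nM.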

Compound 3, half-maximal inhibitory concentration: 48400 nM
The estimate for compound 3 lay 4.0-fold (0.61 log units) below the measured number; the whole stated range lies below it.
By their numbers in this assay, from the lowest: compounds 1 and 2 (each within the scatter of the next); then compound 3.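

Going by these compounds alone, this is the first step that can be read, and it lies beyond the scatter: in this assay, a six-membered non-aromatic ring with 1 hetero atom in place of the five-membered one gives a 3.8-fold higher number from compound 1 to compound 3 (0.58 log units; beyond the scatter), which means weaker inhibition. The same atoms joined differently are thus enough to change the result at this end of the molecule, although the step carries two changes at once, a larger ring and a shorter chain to the aromatic oxygen. Nothing measured here explains the rise.

The compounds shown leave open whether the ring size, the chain length or the two together account for the step, and a pair differing in only one of these would be needed to tell them apart. As far as these compounds go, it also remains open how this position would respond to a morpholine ring, which carries an extra oxygen, or to an open-chain diethylamine in place of the ring, and whether the same step would hold on the shared core of other chalcones.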